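The compounds below may be only part of what the source reports. "The series", "measured", "known", "first", "only" and "open" are said of these compounds alone.

In a physicochemical assay for acid dissociation, compound 1 (`C=C(C)COC[n+]1ccn(C)c1/C=N/O`) gives 7.99 and compound 2 (`CC#CC(C)OC[n+]1ccn(C)c1/C=N/O`) gives 8.03 so compound 2 stands within the scatter of compound 1, and the two numbers cannot be put in order. The next structure is compound 3 (`C#CC(CC)OC[n+]1ccn(C)c1/C=N/O`) which has the same atoms as compound 2, joined differently. The change is a group of 5 heavy atoms (5 carbon; no ring) in place of a group of 5 heavy atoms (5 carbon; no ring), on an oxygen on a saturated carbon and it sits on an oxygen on a saturated carbon. For the measured compounds named here, only one measured step bears on it, a number 0.04 log units higher from compound 1 to compound 2 (within the scatter) and that step also exchanged the group at this place. One step is thin evidence, but it gives no reason to expect a shift beyond the scatter here. The estimated change is a number 0.03 log units lower from compound 2 to compound 3 (within the scatter) and so lies within the scatter. For compound 3 the expected value is 8 with an estimated range from 7.7 to 8.3 in this measurement.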

Compound 3, acid dissociation constant: 7.99
Compound 3: the middle estimate sits 0.01 log units above what was measured; low and high end bracket the measured number.
By their numbers in this assay, from the lowest: compounds 1, 3 and 2 (each within the scatter of the next).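

In this assay, rearranging the five carbons of this group, with one triple bond both before and after, gives a number 0.04 log units lower from compound 2 to compound 3 (within the scatter) and so leaves the two compounds indistinguishable. The exchange of the four-carbon group for the new five-carbon group gives no change at the digits printed from compound 1 to compound 3 (within the scatter) and adds a second such comparison at this place, so all three groups on this oxygen now give numbers that cannot be put in order. No separate measurement bears on why these numbers lie so close.

All three compounds carry a small group made only of carbon and hydrogen at this place, and they share the same core. On these data alone, how the number would respond to an amine, a carboxylic acid or a much longer chain on this oxygen remains open, as does the effect of any change to the core.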